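The source may hold more compounds than are shown below. What is called first, only, known or untested is meant among the compounds shown, and "the series" means these compounds.

In a functional assay on K562 cells (Homo sapiens) for cytotoxicity, read by sulforhodamine B assay, with a stated time of 48 h, tested at 10 uM (on this read-out lower numbers stand for a stronger effect and higher numbers for a weaker effect at the one concentration tested), compound 2 `Cc1cc(O)cc(-c2nn(CC#N)cc2-c2ccnc(-c3ccc(Oc4ccccc4)cc3)c2)c1` gives -2%, the lower of the two numbers. Compound 1 `COc1cc(C)cc(-c2c(-c3ccnc(-c4ccc(C(C)=O)cc4)c3)cnn2CC#N)c1` in this assay gives 15%, a gap that lies beyond the scatter. Compound 3 `Cc1cc(O)cc(-c2nn(CC#N)cc2-c2ccnc(-c3ccc(N(C)C)cc3)c2)c1` differs from compound 2 by dimethylamino in place of phenoxy on an aromatic carbon. Among the compounds with values here, no measured pair shows this particular change, so its effect in this assay is not known from the data. Compound 3 is therefore expected to stay close to compound 2, with the step of a number 6 percentage points higher from compound 2 to compound 3 (within the scatter) expected to fall within the scatter. The estimate for compound 3 in this assay is 4%, with a range from -14% to 24%.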

Compound 3, a percentage reported as activity, at one concentration (the size of the read-out at that concentration, not a potency): -6%
For compound 3 the middle estimate is 10 percentage points above the measured one, within the range that was stated.
By their numbers in this assay, from the lowest: compounds 3 and 2 (each within the scatter of the next); then compound 1.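

In this assay, dimethylamino in place of phenoxy on an aromatic carbon, para to a large group, gives a number 4 percentage points lower from compound 2 to compound 3 (within the scatter). This single-place pair shows that the aromatic ring of phenoxy can give way to a smaller group with no ring, and the read-out does not separate compound 2 from compound 3. No available evidence bears on this result. Whether a carboxylic acid or a morpholine ring at this place would stay in the same range remains open, as does the behaviour of these compounds at other concentrations.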